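The compounds below may be only part of what the source reports. "The series", "measured", "known", "first", "only" and "open" are said of these compounds alone.

In a functional assay on SMMC-7721 cells (Homo sapiens) for inhibition, read by MTT assay, with a stated time of 72 h, tested at 25 uM (on this read-out higher numbers stand for more inhibition at the one concentration tested (going by the name of the read-out) and lower numbers for less inhibition), compound 2, whose structure is `CCc1nn(C)c(CO/N=C/c2c(C)nn(C)c2Oc2ccc(C)cc2)c1Cl`, gives only a limit of the assay, < 80%. The nearest measured relative is compound 1, `CCc1nn(C)c(CO/N=C/c2c(C)nn(C)c2Oc2ccc(Br)cc2)c1Cl`, which carries bromo where compound 2 carries methyl on an aromatic carbon. In this assay compound 1 also gives only a limit, < 80%. The step that the two limits leave unreadable from compound 1 to compound 2 cannot be sized because of the limit of < 80% in this assay, at which 2 of the 2 values shown sit; no measured value above the limit exists in this set.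

Compound 3, `CCc1nn(C)c(CO/N=C/c2c(C)nn(C)c2Oc2ccccc2C)c1Cl`, keeps every atom of compound 2 but joins them differently: 2-methylphenyl in place of 4-methylphenyl on an oxygen on an aromatic ring. Among the compounds with values here, the only measured step, the exchange of bromo for methyl, is unreadable, so it gives no direction and no size for the new change, and nothing else measured touches the phenyl ring. With both measured compounds sitting at the limit, the plain expectation is that compound 3 remains there too.

Compound 3 is therefore estimated at 40%, within 5% to 78%. The expected step that the limit leaves unreadable from compound 2 to compound 3 amounts to no movement that the scatter could separate, and most likely the assay again reports only a limit.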

Compound 3, a percentage reported as inhibition, at one concentration (the size of the read-out at that concentration, not a potency): < 80%
Compound 3 ended at the assay's limit (the forecaster's own chance of this, stated with the estimate: 80%); the middle value is on the limit's open side.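

No step can be read from compound 2 to compound 3 or from compound 1 to compound 3, since compound 3 also gives only a limit, not a number: the limit of < 80% in this assay, at which 3 of the 3 values shown sit. What the compounds shown leave open is how strongly each one inhibits in this assay, and whether 2-methylphenyl and 4-methylphenyl differ there at all.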